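Working notes: heteroaryl change on the double-bonded chain carbon

This account rests on a few compounds, and the source may have more. Where it says the series, first, only, none or still open, it means among the compounds named here.

Measured so far:
- compound 1 `O=C(/C=C/c1cccc(Br)n1)Nc1ccc2ncnc(Nc3cccc(Cl)c3)c2c1`: 4160 nM in a functional assay on A549 cells (Homo sapiens) for antiproliferative activity, read by MTT assay, with a stated time of 48 h; on this read-out lower numbers stand for stronger inhibition and higher numbers for weaker inhibition
- compound 2 `O=C(/C=C/c1cccs1)Nc1ccc2ncnc(Nc3cccc(Cl)c3)c2c1`: 9310 nM in this assay
- compound 3 `O=C(/C=C/c1c[nH]c2ccccc12)Nc1ccc2ncnc(Nc3cccc(Cl)c3)c2c1`: 3670 nM in this assay

Among the compounds with values here, compound 3 holds the lowest number of the three, though its gap to compound 1 is within the scatter; only the step of a 2.5-fold lower number from compound 2 to compound 3 (0.40 log units; beyond the scatter) lies beyond it. Compound 4 `O=C(/C=C/c1cccnc1Cl)Nc1ccc2ncnc(Nc3cccc(Cl)c3)c2c1` carries 2-chloropyridin-3-yl in place of 1H-indol-3-yl on a double-bonded chain carbon bound to a double-bonded chain carbon. Within the data shown here, the steps that bear on this are a 1.1-fold lower number from compound 1 to compound 3 (0.05 log units; within the scatter), which was within the scatter, and a 2.5-fold lower number from compound 2 to compound 3 (0.40 log units; beyond the scatter), a modest change. Since the incoming group, like that of compound 1, is a halogen-bearing six-membered aromatic ring with one nitrogen, the step of a 1.1-fold lower number from compound 1 to compound 3 (0.05 log units; within the scatter) is the closer guide, and in this assay compound 4 is expected to land near compound 3 and compound 1, with an expected step of a 1.1-fold higher number from compound 3 to compound 4 (0.06 log units; within the scatter). The estimate for compound 4 is 4200 nM, with a range from 2000 nM to 9000 nM.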

Compound 4, half-maximal inhibitory concentration: 2920 nM
Beside the measured number, compound 4's estimate is 1.4-fold (0.16 log units) above it; the measured number falls inside the stated range.
By their numbers in this assay, from the lowest: compounds 4, 3 and 1 (each within the scatter of the next); then compound 2.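

The 2-chloropyridin-3-yl group gives a number in this assay close to those of the two larger-numbered comparisons at this place: a 1.3-fold lower number from compound 3 to compound 4 (0.10 log units; within the scatter) and a 1.4-fold lower number from compound 1 to compound 4 (0.15 log units; within the scatter) show that the hydrogen-bond donor of 1H-indol-3-yl is not needed to stay in this range. Thiophen-2-yl alone stands apart, with a 3.2-fold lower number from compound 2 to compound 4 (0.50 log units; beyond the scatter). Nothing measured here explains these differences.

From the compounds shown here alone, whether an amine or a carboxylic acid at this same place would move the number remains open. So does whether a plain phenyl ring would match the 2-chloropyridin-3-yl group.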